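A few compounds are considered here, and "the series" means these few. Any claim that something is new, unique, unknown or untested is made for them only; others in the source may bear on it.

Measured compounds:
Compound 1, `CC(=O)Nc1ccc(NC(=O)c2cn(Cc3c(F)cccc3Cl)c3ccc(=O)[nH]c3c2=O)cc1` — in an in vitro assay on Sf21 cells for inhibition of high affinity 3',5'-cyclic-AMP phosphodiesterase 7A (Homo sapiens), read by scintillation proximity assay, with a stated time of 30 min (on this read-out lower numbers stand for stronger inhibition and higher numbers for weaker inhibition), compound 1 gives 17 nM.
Compound 2, `CC(=O)c1ccc(NC(=O)c2cn(Cc3c(F)cccc3Cl)c3ccc(=O)[nH]c3c2=O)cc1` — in this assay compound 2 gives 18 nM.

The two compounds share a core and differ only in the group on the aromatic carbon of the aniline-derived amide: acetamido in compound 1, acetyl in compound 2. The step of a 1.1-fold higher number from compound 1 to compound 2 (0.02 log units; within the scatter) shows that this exchange made no difference beyond the scatter. Compound 2 carries the higher of the two numbers, but its distance from compound 1 is well inside the scatter, so the two compounds cannot be told apart on these data.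

Compound 3, `NC(=O)c1cccc(NC(=O)c2cn(Cc3c(F)cccc3Cl)c3ccc(=O)[nH]c3c2=O)c1`, has not yet been measured. It differs from compound 2 by 3-carbamoylphenyl in place of 4-acetylphenyl on an amide-type nitrogen. For the measured compounds named here, the only measured step, from compound 1 to compound 2, concerns an exchange of the group on the aromatic ring at the same position as the acetyl of compound 2; it was within the scatter. Going by the values given here, no measured step addresses a carbamoyl group or a move of the substituent to the 3-position of the phenyl ring. Compound 3 is therefore expected to show a step of a 1.7-fold higher number from compound 2 to compound 3 (0.22 log units; within the scatter) in this assay, a small weakening that may well lie within the scatter. The estimate for compound 3 in this assay is 30 nM, with a range from 10 nM to 100 nM.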

Compound 3, half-maximal inhibitory concentration: 44 nM
Beside the measured number, compound 3's estimate is 1.5-fold (0.17 log units) below it; measured number inside the range.
By their numbers in this assay, from the lowest: compounds 1 and 2 (each within the scatter of the next); then compound 3.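

Replacing 4-acetylphenyl with 3-carbamoylphenyl on the amide-type nitrogen gives a 2.4-fold higher number from compound 2 to compound 3 (0.39 log units; beyond the scatter) in this assay and replacing 4-acetamidophenyl with the same group gives a 2.6-fold higher number from compound 1 to compound 3 (0.41 log units; beyond the scatter) on the same read-out. Both steps are modest but beyond the scatter, whereas the exchange of acetamido for acetyl stayed within it, so this position is not indifferent to every change of its aryl group. The change alters both the group and where it sits on the ring, however, so these compounds cannot show which of the two accounts for the step. Nothing measured here explains the step.

As far as these compounds go, it remains open whether 4-carbamoylphenyl would read like compound 1 and compound 2 or like compound 3, and whether 3-acetylphenyl would do the same, which would separate the effect of the group from that of its place on the ring. From the compounds shown here alone, it is also open how a carboxylic acid or an amine on this ring would read.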